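Benzyl Ether Variant Weighed Against Three Cytotoxicity Limits

This account rests on a few compounds, and the source may have more. Where it says the series, first, only, none or still open, it means among the compounds named here.

Compound 2 `CCCCCCOc1ccc(C(O)C2OC(=O)c3c(OC)cc(OC)cc32)cc1` stands at the edge of what an ADME assay on RAW264.7 cells (Mus musculus) for cytotoxicity, read by MTT assay, with a stated time of 24 h, in the presence of a further agent that is not named here (on this read-out lower numbers stand for stronger inhibition and higher numbers for weaker inhibition), can report: in this assay compound 2 gives > 40000 nM, which is a limit of the measurement and not a number. Compound 3 `COCCCOc1ccc(C(O)C2OC(=O)c3c(OC)cc(OC)cc32)cc1` in this assay likewise gives > 40000 nM, a limit. Compound 1 `O=C1OC(Cc2nc(-c3ccc(-c4ccccc4)cc3)no2)c2ccccc21`, built on a different core, in this assay gives > 40000 nM, again a limit. For the measured compounds named here, the one step among the measured compounds, a step that the two limits leave unreadable from compound 2 to compound 3, is therefore unreadable in both size and direction.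

The unmeasured compound 4 `COc1cc(OC)c2c(c1)C(C(O)c1ccc(OCc3ccc(C)cc3)cc1)OC2=O` differs from compound 2 in one place: 4-methylphenyl in place of pentyl on a saturated chain carbon bound to an oxygen on an aromatic ring. Cut one bond further out, the same change reads hexyloxy to (4-methylbenzyl)oxy. Going by the values given here, no measured step covers this change, and because the limit of > 40000 nM in this assay, at which 3 of the 3 values shown sit, there is no value anywhere in the set from which a step beyond the scatter, in either direction, could be founded. The step of a number no higher from compound 2 to compound 4 (the limit leaves the size open) is accordingly expected to be none beyond the scatter. Compound 4 is therefore estimated to give 40000 nM in this assay, within a range from 20000 nM to 200000 nM, and most probably the assay will again report only a limit.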

Compound 4, half-maximal inhibitory concentration: > 40000 nM
Compound 4: a limit, no number; the forecaster's own chance of this, stated with the estimate: 85%; the middle value lies on the limit itself.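

In this assay compound 4 gives > 40000 nM, which is a limit and not a number. The steps linking compound 4 with compound 2 and compound 3 cannot be read, for the following reason: the limit of > 40000 nM in this assay, at which 4 of the 4 values shown sit.

The compounds shown leave open what value any of them would give, and whether hexyloxy and (4-methylbenzyl)oxy differ at all in this read-out.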